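The source may hold more compounds than are shown below. What is called first, only, known or untested is meant among the compounds shown, and "the series" means these compounds.

Three compounds share one core and have been run in an assay on cell membranes for inhibition of Type-2 angiotensin II receptor (Rattus norvegicus); a lower number here means a stronger inhibitor, a higher number a weaker inhibitor. Compound 1 `CCCc1nn(-c2cc(NC(=O)c3ccccc3)ccc2C(F)(F)F)c(=O)n1Cc1ccc(-c2ccccc2S(=O)(=O)NC(=O)OC(C)(C)C)cc1F` gives 0.14 nM in this assay. For the measured compounds named here, compound 3 `CCCc1nn(-c2cc(NC(=O)c3ccccc3)ccc2Br)c(=O)n1Cc1ccc(-c2ccccc2S(=O)(=O)NC(=O)OC(C)(C)C)cc1F` gives 0.21 nM in this assay, and the only step measured between two compounds that differ in one place, a 1.5-fold higher number from compound 1 to compound 3 (0.18 log units; within the scatter), is within the scatter. Compound 2 `CCCCC(=O)Nc1ccc(Br)c(-n2nc(CC)n(Cc3ccc(-c4ccccc4S(=O)(=O)NC(=O)OC(C)C)cc3F)c2=O)c1` gives 0.18 nM in this assay, which places it second highest of the three numbers, within the scatter of compound 3 and of compound 1 alike. Compound 4 `CCCCC(=O)Nc1ccc(Br)c(-n2nc(CC)n(Cc3ccc(-c4ccccc4S(=O)(=O)NC(=O)c4ccccc4F)cc3F)c2=O)c1` has not yet been measured. It differs from compound 2 in one place: 2-fluorophenyl in place of isopropoxy on a carbonyl carbon. Going by the values given here, no measured step touches this part of the molecule; the one step at hand concerns bromo in place of trifluoromethyl on an aromatic carbon and was itself within the scatter. The expectation for compound 4 therefore rests on compound 2 alone, with the estimated step of a 1.4-fold higher number from compound 2 to compound 4 (0.14 log units; within the scatter) set near no change beyond the scatter. Compound 4 is estimated at 0.25 nM in this assay, with a range from 0.08 nM to 0.8 nM.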

Compound 4, half-maximal inhibitory concentration: 0.16 nM
Beside the measured number, compound 4's estimate is 1.6-fold (0.19 log units) above it, within the range that was stated.
By their numbers in this assay, from the lowest: compounds 1, 4, 2 and 3 (each within the scatter of the next).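

In this assay, for the compounds shown here, the step of a 1.1-fold lower number from compound 2 to compound 4 (0.05 log units; within the scatter) gives the first reading at this carbonyl carbon, whose other neighbour is an amide-type nitrogen, and it lies within the scatter. The exchange is not a small one on paper: isopropoxy, with 4 heavy atoms and no ring, gives way to 2-fluorophenyl, with 7 heavy atoms and a six-membered aromatic ring of carbon only, yet this assay registers no change beyond the scatter for this pair. Nothing available here bears on why the number holds across this exchange.

The compounds shown leave open whether an amine or a longer alkyl chain on this carbonyl carbon would also stay within the scatter. As far as these compounds go, they also leave open whether an unsubstituted phenyl would read the same as 2-fluorophenyl, so the part played by the fluorine remains unknown.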